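The source may hold more compounds than are shown below. What is called first, only, known or untested is meant among the compounds shown, and "the series" means these compounds.

Measured so far in a physicochemical assay for solubility, in phosphate buffer, measured as kinetic solubility, with a stated time of 1 h, at pH 7.4; on this read-out higher numbers stand for higher solubility and lower numbers for lower solubility:
- compound 1 `COc1ccc2nc(C)cc(OCC(=O)Nc3cc(C)ccc3C)c2c1`: 45500 nM
- compound 2 `COc1ccc2nc(C)cc(OCC(=O)Nc3ccc(Cl)c(OC)c3)c2c1`: 13000 nM

Compound 2 holds the lowest of the two numbers; the nearest is compound 1, which gives the higher value shown above. Within the data shown here, the only measured step that touches the same position is the one from compound 1 to compound 2, a 3.5-fold lower number from compound 1 to compound 2 (0.54 log units; beyond the scatter), where the group on the amide-type nitrogen was exchanged while the shared core was kept.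

Compound 3 `COc1ccc2nc(C)cc(OCC(=O)Nc3cc(C)nc(C)n3)c2c1` changes that same position again: 2,6-dimethylpyrimidin-4-yl in place of 4-chloro-3-methoxyphenyl on an amide-type nitrogen. Among the measured compounds shown here, the single relevant step was of modest size, so a step of comparable size is expected here, while its direction is not settled by one measurement. Taking compound 2 as the starting point, the expected change is a 2.3-fold higher number from compound 2 to compound 3 (0.36 log units; beyond the scatter). For compound 3 the estimate in this assay is 30000 nM, with a range from 10000 nM to 90000 nM.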

Compound 3, solubility: 5000 nM
For compound 3 the middle estimate is 6.0-fold (0.78 log units) above the measured one; the whole stated range lies above it.
By their numbers in this assay, from the lowest: compound 3; then compound 2; then compound 1.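

In this assay, the step of a 2.6-fold lower number from compound 2 to compound 3 (0.41 log units; beyond the scatter) shows that a ring with 2 hetero atoms on the amide-type nitrogen does not lift the number above that of either carbon-only ring shown. The step of a 9.1-fold lower number from compound 1 to compound 3 (0.96 log units; beyond the scatter) is the widest shown at this position, and it places 2,6-dimethylpyrimidin-4-yl lowest of the three groups, with both steps beyond the scatter. No measurement bearing on the reason for this result is available.

The three compounds do not separate the contribution of the ring nitrogens from that of the two methyl groups on the ring. Going by these compounds, it also remains open where an unsubstituted pyridine ring, or a phenyl ring carrying a carboxylic acid or an amine, would fall on the amide-type nitrogen.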